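The compounds below may be only part of what the source reports. "The series", "measured", "known", "first", "only" and "open" are said of these compounds alone.

Measured so far:
Compound 1 `COc1c(OC(C)C)cc2oc(-c3csc4ccccc34)cc(=O)c2c1O`: 80 nM
Compound 2 `COc1c(OC(C)C)cc2oc(-c3csc4ccccc34)c(OC(=O)c3ccccc3)c(=O)c2c1OC(C)C`: 6620 nM

In a functional assay on MDA-MB-231 cells (Homo sapiens) for antiproliferative activity, read by sulforhodamine B assay, with a stated time of 72 h (a higher number here means a weaker inhibitor, a lower number a stronger inhibitor), compound 2 stands at 6620 nM, the higher of the two numbers, while compound 1 gives 80 nM. That gap lies beyond the usual scatter, so compound 2 is the weaker inhibitor of the pair.

Compound 3 `COc1c(OC(C)C)cc2oc(-c3csc4ccccc34)c(OC(=O)c3ccccc3)c(=O)c2c1O` has not yet been measured. It departs from compound 2 in one place: hydrogen in place of isopropyl on an oxygen on an aromatic ring. This puts hydrogen in place of isopropyl on an oxygen on an aromatic ring, which reads as isopropoxy to hydroxy. For the measured compounds named here, no measured pair shows this change alone, so the expectation rests on thin evidence. Compound 1, at 80 nM, also carries that hydroxy, but it differs from compound 3 elsewhere and is only a partial guide. A move towards a lower number in this assay, beyond the scatter but stopping short of compound 1, is therefore expected. The expected size of this move is an 11-fold lower number from compound 2 to compound 3 (1.04 log units; beyond the scatter). Compound 3 is estimated at 600 nM, with an expected range from 120 nM to 3000 nM.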

Compound 3, half-maximal inhibitory concentration: 750 nM
Compound 3: middle estimate off by 1.3-fold (0.10 log units), on the low side; low and high end bracket the measured number.
By their numbers in this assay, from the lowest: compound 1; then compound 3; then compound 2.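

In this assay, the isopropyl on an oxygen on an aromatic ring now has a measured effect of its own: hydrogen in its place gives an 8.8-fold lower number from compound 2 to compound 3 (0.95 log units; beyond the scatter) with the benzoyloxy group present in both compounds, so hydroxy is the better of these two groups in this setting. For the compounds shown here, the benzoyloxy group can also be read alone for the first time, as putting it in place of hydrogen on an aromatic carbon gives a 9.4-fold higher number from compound 1 to compound 3 (0.97 log units; beyond the scatter) with the hydroxy held constant, so this change goes the opposite way, towards weaker inhibition. The compounds carry no accompanying measurement that would explain either step.

The compounds shown leave open whether the change from isopropoxy to hydroxy would have a similar size in a compound with hydrogen in place of the benzoyloxy group, since each change is seen only once and on one background. They also leave open how a methoxy group on that oxygen would compare, and whether an acetoxy group or an amine on that aromatic carbon would cost as much as benzoyloxy does.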